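The source may hold more compounds than are shown below. What is called first, only, known or untested is meant among the compounds shown, and "the series" means these compounds.

Measured in an in vitro assay on CHO-KI cells for displacement of a labelled ligand from prostaglandin F2-alpha receptor (Homo sapiens); on this read-out higher numbers stand for weaker inhibition and lower numbers for stronger inhibition:
compound 1 `O=C(O)CCCCCC[C@@H]1[C@@H](CC[C@@H](O)CCc2cccc(F)c2)[C@H](O)C[C@@H]1O` gives 42 nM;
compound 2 `O=C(O)CCCCCC[C@@H]1[C@@H](CC[C@@H](O)CCc2ccc(F)cc2)[C@H](O)C[C@@H]1O` gives 210 nM;
compound 3 `Cc1ccccc1CC[C@H](O)CC[C@@H]1[C@@H](CCCCCCC(=O)O)[C@@H](O)C[C@H]1O` gives 630 nM.

Compound 3 stands highest of the three numbers in this assay, with compound 2 nearest and compound 1 furthest. The step to compound 4 `Cc1ccc(CC[C@H](O)CC[C@@H]2[C@@H](CCCCCCC(=O)O)[C@@H](O)C[C@H]2O)cc1` is 4-methylphenyl in place of 2-methylphenyl on a saturated chain carbon, three bonds along the chain from an oxygen on a saturated carbon. Among the measured compounds shown here, no measured step turns one methylphenyl into another, so the bearing is indirect: a 5.0-fold higher number from compound 1 to compound 2 (0.70 log units; beyond the scatter) shows that exchanging one fluorophenyl for another can move the number by a modest amount, while a 15-fold higher number from compound 1 to compound 3 (1.18 log units; beyond the scatter) and a 3.0-fold higher number from compound 2 to compound 3 (0.48 log units; beyond the scatter) combine a change of group with a change of its kind. The expected step for compound 4 is a 1.4-fold lower number from compound 3 to compound 4 (0.15 log units; within the scatter), and it is not expected to go far beyond the scatter. The estimate for compound 4 is 450 nM, within 120 nM to 1800 nM.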

Compound 4, half-maximal inhibitory concentration: 4400 nM
The estimate for compound 4 lay 9.8-fold (0.99 log units) below the measured number; measured number above the stated range.
By their numbers in this assay, from the lowest: compound 1; then compound 2; then compound 3; then compound 4.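

In this assay the place of the methyl on the phenyl ring matters, with a 7.0-fold higher number from compound 3 to compound 4 (0.84 log units; beyond the scatter) for a change that leaves the atoms the same. Methyl in place of fluoro on an aromatic carbon gives a 21-fold higher number from compound 2 to compound 4 (1.32 log units; beyond the scatter) and is no small change here, and the widest gap of the set is a 100-fold higher number from compound 1 to compound 4 (2.02 log units; beyond the scatter) on going from 3-fluorophenyl to 4-methylphenyl. How 3-methylphenyl or 2-fluorophenyl would fit into this order remains open, and no measurement at hand explains the differences between these groups.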